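A few compounds are considered here, and "the series" means these few. Any claim that something is new, unique, unknown or untested is made for them only; others in the source may bear on it.

Working notes on the series.

Among the measured compounds shown here, compound 1 `CC(C)CC1(O)CCN(C(=O)Nc2cc(Oc3ccc(C(=O)O)cc3)cc(Oc3ccc(F)cc3F)c2)CC1` gives 65 ng.h/mL in an ADME assay on the whole organism for pharmacokinetics, with Rattus norvegicus as the target, with a stated time of 24 h, at a dose of 1 mg/kg by the oral route (on this read-out lower numbers stand for lower exposure and higher numbers for higher exposure at the dose given), the lowest of the three numbers so far. Compound 2 `CC(C)CC1(O)CCN(C(=O)Nc2cc(Oc3ccc(F)cc3)cc(Oc3ccc(C(C)(C)C(=O)O)cc3)c2)CC1` gives 390 ng.h/mL and compound 3 `CC(C)CC1(O)CN(C(=O)Nc2cc(Oc3ccc(F)cc3)cc(Oc3ccc(C(C)(C)C(=O)O)cc3)c2)C1` gives 1060 ng.h/mL; compound 1 and compound 2 differ in more than one place, so the gap between them is only recorded, not attributed. For the measured compounds named here, the one single-point step measured is a 2.7-fold higher number from compound 2 to compound 3 (0.43 log units; beyond the scatter), a change in the ring attached to the carbonyl carbon.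

Compound 4 `CC(C)CC1(O)CCN(C(=O)Nc2cc(Oc3ccc(C(=O)O)cc3)cc(Oc3ccc(F)c(F)c3)c2)CC1` differs from compound 1 by 3,4-difluorophenyl in place of 2,4-difluorophenyl on an oxygen on an aromatic ring. Going by the values given here, none of the measured steps touches the fluorine pattern on this ring; the step between compound 2 and compound 3 concerns a different part of the molecule and gives no guide here. Among the compounds with values here, with no step bearing on the change, the expectation for compound 4 is a number close to that of compound 1, i.e. a step of a 1.2-fold higher number from compound 1 to compound 4 (0.09 log units; within the scatter) expected to stay within the scatter in this assay. Compound 4 is therefore estimated at 80 ng.h/mL, with a range from 25 ng.h/mL to 250 ng.h/mL.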

Compound 4, area under the concentration-time curve: 62 ng.h/mL
Compound 4: middle estimate off by 1.3-fold (0.11 log units), on the high side; measured number inside the range.
By their numbers in this assay, from the lowest: compounds 4 and 1 (each within the scatter of the next); then compound 2; then compound 3.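

In this assay, among the compounds shown here, 3,4-difluorophenyl in place of 2,4-difluorophenyl on an oxygen on an aromatic ring gives a 1.0-fold lower number from compound 1 to compound 4 (0.02 log units; within the scatter), the only measured step on this ring. For this pair, the two fluorine patterns cannot be told apart at this position, so the low exposure of compound 1 is not specific to the 2,4-difluorophenyl pattern. Nothing measured here explains why the two patterns read alike.

As far as these compounds go, a phenyl ring carrying a nitrile or methoxy group, or a pyridine ring, on this oxygen remains open. Also open, from the compounds shown here alone, is whether the same fluorine change reads alike with the carboxylic acid side of compound 2 or the 3-hydroxy-3-isobutylazetidin-1-yl group of compound 3.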